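An Open Chain in Place of a Ring on Compound 2

The source may hold more compounds than are shown below. What is called first, only, known or untested is meant among the compounds shown, and "the series" means these compounds.

compound 1 `CC(=O)Nc1nc(CCc2ccc(NC3=NCCS3)cc2)cs1` — 3500 nM
compound 2 `CC(=O)Nc1nc(CCc2ccc(NC3=NCCN3)cc2)cs1` — 3000 nM

Of the compounds shown here, two have so far been measured in an assay on CHO cells for inhibition of Amine oxidase [copper-containing] 3 (Homo sapiens), read by spectrophotometry, with stated times of 30 min and 1 h; on this read-out higher numbers stand for weaker inhibition and lower numbers for stronger inhibition. Compound 1 gives 3500 nM in this assay, and compound 2 gives 3000 nM. The step of a 1.2-fold lower number from compound 1 to compound 2 (0.07 log units; within the scatter) exchanged one five-membered ring for another on the nitrogen on the aromatic ring and left the number essentially where it was. Compound 2 holds the lower of the two numbers, but since its distance to compound 1 lies within the scatter, no order between them can be claimed.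

Compound 3 `CC(=O)Nc1nc(CCc2ccc(NC(=N)N(C)C)cc2)cs1` differs from compound 2 in a group of 5 heavy atoms (3 carbon, 2 nitrogen; no ring) in place of a group of 5 heavy atoms (3 carbon, 2 nitrogen; one five-membered non-aromatic ring with 2 hetero atoms), on a nitrogen on an aromatic ring. Going by the values given here, the only measured step at this place is a 1.2-fold lower number from compound 1 to compound 2 (0.07 log units; within the scatter); it bears on the change in that it also swapped the group on this nitrogen, yet it kept a ring where compound 3 opens one, so it guides only loosely. The expectation is therefore a step no larger than the scatter, if anything a slightly higher number, written as a 1.3-fold higher number from compound 2 to compound 3 (0.12 log units; within the scatter). Compound 3 is estimated at 4000 nM, with a range from 1500 nM to 11000 nM.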

Compound 3, half-maximal inhibitory concentration: > 100000 nM
Compound 3: no number, only a limit (the forecaster's own chance of this, stated with the estimate: 10%); middle value at least 25-fold (1.39 log units) away from the limit.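

Where one five-membered ring had replaced another on the nitrogen on the aromatic ring with only a 1.2-fold lower number from compound 1 to compound 2 (0.07 log units; within the scatter), the open group with the same count of heavy atoms brought an at least 33-fold higher number from compound 2 to compound 3 (1.52 log units; beyond the scatter), and set against the sulfur-containing ring it brought an at least 28-fold higher number from compound 1 to compound 3 (1.45 log units; beyond the scatter). In this assay compound 3 has no number, only a limit of the assay: the limit of > 100000 nM in this assay, at which 1 of the 3 values shown sits. This position is therefore not indifferent to what it carries, since the two ring-bearing compounds lie within the scatter of each other while the open group lies beyond the scatter from both.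

Going by these compounds alone, the three compounds do not tell how far the open group really lies from the rings, nor do they separate the removal of the ring from the presence of the methyl groups on the open group, as the single change does both at once. An unsubstituted guanidine or a six-membered ring on the same nitrogen would speak to that question.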